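The compounds below may be only part of what the source reports. "The series", "measured", "known", "first", "only" and "open" are said of these compounds alone.

Compound 1 `CS(=O)(=O)c1ccc(C(=O)N2CCC(C(=O)N3CCN(c4ccc(F)cc4)CC3)CC2)cc1[N+](=O)[O-]`: in an ADME assay on HepG2 cells (Homo sapiens) for cytotoxicity, read by CellTiter-Glo and ATP content, with a stated time of 72 h (a higher number here means that more compound is needed for the effect, a lower number that less compound is needed), compound 1 gives > 27000 nM, which is a limit of the assay and not a number.
Compound 2 `CN(Cc1ccccc1F)C(=O)C1CCN(C(=O)c2ccc(S(C)(=O)=O)c([N+](=O)[O-])c2)CC1`: in this assay compound 2 gives > 27000 nM, again a limit of the assay.
Compound 3 `CC1CCN(C(=O)CCNC(=O)c2ccc(S(C)(=O)=O)c([N+](=O)[O-])c2)CC1`: in this assay compound 3 gives > 27000 nM, again a limit of the assay.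

Compound 2 therefore stands at the limit of this assay, and no number is known for it. The two further values shown are limits as well, so none of the three compounds can be placed above or below another; all that the set shows is the limit of > 27000 nM in this assay, at which 3 of the 3 values shown sit.

Compound 4 `CS(=O)(=O)c1ccc(C(=O)N2CCC(C(=O)N3CCc4ccccc4C3)CC2)cc1[N+](=O)[O-]` differs from compound 2 in one place: 1,2,3,4-tetrahydroisoquinolin-2-yl in place of (2-fluorobenzyl)(methyl)amino on a carbonyl carbon. The shared core, with its carbonyl and the saturated ring carbon, is untouched. Among the compounds with values here, no step between measured compounds that differ in one place is available here, so there is nothing to show that an exchange of this kind has ever moved the read-out of this assay away from its limit.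

On that basis the expected step of a number no higher from compound 2 to compound 4 (the limit leaves the size open) is none beyond the usual scatter. Compound 4 is expected to give 27000 nM in this assay, with a range from 18000 nM to 40000 nM, and most likely to be reported only as a limit.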

Compound 4, half-maximal effective concentration: > 27000 nM
Compound 4: a limit, no number; the forecaster's own chance of this, stated with the estimate: 85%; the middle value sits exactly at the limit.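

Compound 2 and compound 4 both stand at a limit of this assay and not at a number, so no step can be read from one to the other. The compounds shown leave open what number any of them would give, and whether any change in structure moves the read-out away from what they share: the limit of > 27000 nM in this assay, at which 4 of the 4 values shown sit.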